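The source may hold more compounds than are shown below. What is called first, only, known or untested is meant among the compounds shown, and "the series" means these compounds.

Measured so far:
- compound 1 `C=C1C(=O)OC(C)CC1c1ccc([N+](=O)[O-])cc1`; in a functional assay on HL-60 cells (Homo sapiens) for cytotoxicity, read by MTT assay, with a stated time of 48 h (a lower number here means a stronger inhibitor, a higher number a weaker inhibitor), compound 1 gives 6120 nM
- compound 2 `C=C1C(=O)O[C@H](C)[C@@H]1c1ccc([N+](=O)[O-])cc1`; in this assay compound 2 gives 21700 nM

Compound 2 stands at the higher of the two numbers shown. Compound 1, the nearest, sits at the lower number, and the gap between the two lies beyond the usual scatter of this assay. For the measured compounds named here, no pair of measured compounds differing in one place is available, so no measured step can be drawn on.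

Compound 3 `C=C1C(=O)O[C@H](C)[C@@H]1c1ccc(Br)cc1` differs from compound 2 by bromo in place of nitro on an aromatic carbon. Going by the values given here, nothing among the measured compounds shows what this exchange does in this assay. The expectation is a step of modest size, if any, and without a firm direction: the estimated step from compound 2 to compound 3 is a 1.4-fold lower number from compound 2 to compound 3 (0.13 log units; within the scatter). For compound 3 the estimate in this assay is 16000 nM, with a range from 5000 nM to 50000 nM.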

Compound 3, half-maximal inhibitory concentration: 4280 nM
For compound 3 the middle estimate is 3.7-fold (0.57 log units) above the measured one, outside the stated range (below it).
By their numbers in this assay, from the lowest: compounds 3 and 1 (each within the scatter of the next); then compound 2.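

For the compounds shown here, on this aromatic carbon the group carried matters: bromo in place of nitro gives a 5.1-fold lower number from compound 2 to compound 3 (0.71 log units; beyond the scatter) in this assay, the first measured step. The exchange removes a group of 3 heavy atoms with 2 hydrogen-bond acceptors and puts in a single bromine with none, and the number falls rather than rises, so nitro is not required at this place for activity in this cell assay. No measurement at hand gives a reason for this step.

Going by these compounds, whether an amine, a carboxylic acid or a methoxy group on the same aromatic carbon would give a lower or a higher number remains open. On these data alone, it is also open whether the same exchange gives a step of similar size on the core of compound 1.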